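Methyl in place of chloro: compound 3 to compound 4

The compounds below may be only part of what the source reports. "The series", "measured", "known", "first", "only" and "open" are said of these compounds alone.

In a functional assay on CCRF-CEM cells (Homo sapiens) for inhibition (a higher number here means a weaker inhibitor, a lower number a stronger inhibitor), compound 1 `O=C1/C(=C/c2ccc(Br)cc2)CCc2ccccc21` gives > 500000 nM, which is a limit of the assay and not a number. Compound 2 `O=C1/C(=C/c2ccc(F)cc2)CCCc2ccccc21` gives 20000 nM. Compound 3 `O=C1/C(=C/c2cccc(Cl)c2)CCCc2ccccc21` gives 9440 nM, the lower of the two actual numbers, and its gap to compound 2 lies beyond the scatter.

Compound 4 `Cc1cccc(/C=C2\CCCc3ccccc3C2=O)c1` has methyl in place of chloro on an aromatic carbon, meta to a large group: methyl in place of chloro on an aromatic carbon. Among the compounds with values here, no measured pair isolates this change, so the expectation is loose. No step beyond the scatter is expected in this assay, with a slightly higher number the likelier direction. The estimated step is a 1.4-fold higher number from compound 3 to compound 4 (0.14 log units; within the scatter). For compound 4 the estimated value is 13000 nM, with an expected range of 5000 nM to 40000 nM.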

Compound 4, half-maximal inhibitory concentration: 15800 nM
The estimate for compound 4 lay 1.2-fold (0.08 log units) below the measured number; the range from low to high includes it.
By their numbers in this assay, from the lowest: compounds 3, 4 and 2 (each within the scatter of the next, the first and the last beyond it). At a limit, above all of these: compound 1.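

In this assay, methyl in place of chloro on an aromatic carbon, meta to a large group, gives a 1.7-fold higher number from compound 3 to compound 4 (0.22 log units; within the scatter). Within the data shown here, this is the first pair that isolates a single change, and at this position the step does not separate the two groups. Nothing measured here accounts for the step.

Still open, on these data alone, is whether an amine or a carboxylic acid in the same place would stay within the scatter of compound 3. Also open, as far as these compounds go, is whether methyl in place of chloro behaves alike on a different core.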